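Trading a methyl for hydrogen on the phenol oxygen

A few compounds are considered here, and "the series" means these few. Any claim that something is new, unique, unknown or untested is made for them only; others in the source may bear on it.

Of the compounds shown here, three have been measured in a functional assay on U-373MG ATCC cells (Homo sapiens) for inhibition, read by colorimetric assay and MTT assay, with a stated time of 72 h; a lower number here means a stronger inhibitor, a higher number a weaker inhibitor. Compound 1 `COc1cc(C(=O)NNC(=S)Nc2csc(-c3ccc(C)cc3)c2)cc(OC)c1OC` gives 47000 nM, compound 2 `COc1ccc(C(=O)NNC(=S)Nc2csc(-c3ccccc3)c2)cc1` gives 41000 nM, and compound 3 `COc1ccc(C(=O)NNC(=S)Nc2csc(-c3ccc(C)cc3)c2)cc1` gives 19000 nM. Compound 3 has the lowest number of the three: compound 2 sits nearest, and compound 1 furthest, both beyond the scatter. Going by the values given here, the one single-point step measured so far, a 2.2-fold lower number from compound 2 to compound 3 (0.33 log units; beyond the scatter), concerns a methyl added to an aromatic carbon.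

Compound 4 `Cc1ccc(-c2cc(NC(=S)NNC(=O)c3ccc(O)cc3)cs2)cc1` differs from compound 3 in one place: hydrogen in place of methyl on an oxygen on an aromatic ring. Among the compounds with values here, no measured step touches an oxygen substituent; the only measured step, a 2.2-fold lower number from compound 2 to compound 3 (0.33 log units; beyond the scatter), changes a carbon elsewhere and so says little about the present change. Compound 1 and compound 3 differ at several positions at once, so their values cannot be read as a single step either. With nothing to anchor the direction, the expectation for compound 4 is a value near compound 3, with a step of a 1.2-fold higher number from compound 3 to compound 4 (0.06 log units; within the scatter) that may fall within the scatter in either direction. Compound 4 is therefore estimated at 22000 nM, with a likely range from 7000 nM to 70000 nM in this assay.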

Compound 4, half-maximal inhibitory concentration: 64000 nM
Beside the measured number, compound 4's estimate is 2.9-fold (0.46 log units) below it; measured number inside the range.
By their numbers in this assay, from the lowest: compound 3; then compounds 2, 1 and 4 (each within the scatter of the next).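

In this assay, the oxygen substituent proves not to be a neutral spot: going from 4-methoxyphenyl to 4-hydroxyphenyl gives a 3.4-fold higher number from compound 3 to compound 4 (0.53 log units; beyond the scatter), so compound 3 loses inhibition when this methyl is replaced by hydrogen. Going by these compounds alone, this is the first measured step at this oxygen, and, as in a 2.2-fold lower number from compound 2 to compound 3 (0.33 log units; beyond the scatter), the compound carrying the methyl has the lower number, although the two methyls sit in different places and two steps make no general rule. No measurement shown explains why this change weakens inhibition in these cells.

The compounds shown leave open whether a larger group on this oxygen, such as an ethoxy group, would lower the number further, or whether an amine in place of the methoxy group would behave like the hydroxy group of compound 4. They also leave open whether the same swap of methoxy to hydroxy would have a similar effect on the core of compound 2, where the methyl of compound 3 is absent.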